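The source may hold more compounds than are shown below. What is called first, only, known or untested is meant among the compounds shown, and "the series" means these compounds.

In an ADME assay on NIH3T3 cells (Mus musculus) for inhibition, read by MTT assay, with a stated time of 48 h (on this read-out higher numbers stand for weaker inhibition and lower numbers for stronger inhibition), compound 1 (`CCc1ccc(-c2nc3ccccn3c2Sc2ccccc2)cc1`) gives > 100000 nM, which is a limit of the assay and not a number. Compound 2 (`COc1cccc(OC)c1-c1nc2ccccn2c1Sc1ccccc1`) gives > 100000 nM, also a limit. Together the two compounds show (the limit of > 100000 nM in this assay, at which 2 of the 2 values shown sit), so compound 1 has a lower bound on its half-maximal inhibitory concentration but no exact value, and no measured step between compounds is available.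

The next compound to be tested is compound 3 (`c1ccc(Sc2c(-c3ccsc3)nc3ccccn23)cc1`). It carries thiophen-3-yl in place of 4-ethylphenyl on an aromatic carbon, next to the ring atom that bears a phenylsulfanyl group: thiophen-3-yl in place of 4-ethylphenyl on an aromatic carbon. The shared core and the phenylsulfanyl group stay as they are in compound 1.

Among the compounds with values here, the expectation rests on compound 1 at > 100000 nM, the only reference for this change. No step beyond the usual scatter is expected in this assay, in either direction, and the estimated change is a number no higher from compound 1 to compound 3 (the limit leaves the size open). The assay may well report only a limit again. For compound 3 the expected value is 100000 nM, with an estimated range of 50000 nM to 200000 nM.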

Compound 3, half-maximal inhibitory concentration: 94100 nM
For compound 3 the middle estimate is 1.1-fold (0.03 log units) above the measured one; low and high end bracket the measured number.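

Compound 3 is the first compound shown to give a number rather than a limit in this assay, and on this aromatic carbon of the shared core compound 3 gives 94100 nM. Replacing 4-ethylphenyl, a six-membered aromatic ring of carbon only, with thiophen-3-yl, a five-membered aromatic ring with 1 hetero atom, gives an at least 1.0-fold lower number from compound 1 to compound 3 (0.02 log units; that floor lies within the scatter), and this one-sided step does not fix the true size of the change, which may or may not go beyond the usual scatter. The compounds shown therefore stay at or close to the top of the range that can be read, and the series as a whole still offers little exact information: the limit of > 100000 nM in this assay, at which 2 of the 3 values shown sit.

The compounds shown leave open whether any group on this aromatic carbon can bring the number clearly down, for example a phenyl ring carrying an amine or a carboxylic acid, or a ring carrying a longer chain in place of the ethyl group. They also leave open what happens when the phenylsulfanyl group is changed while thiophen-3-yl stays in place.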